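The source may hold more compounds than are shown below. What is called first, only, known or untested is meant among the compounds shown, and "the series" means these compounds.

Three analogues of a shared core have been run in a functional assay on DU-145 cells (Homo sapiens) for antiproliferative activity, read by MTT assay, with a stated time of 24 h; a higher number here means a weaker inhibitor, a lower number a stronger inhibitor. Compound 1 `COc1ccc(-c2cc(/C=C/C(=O)c3ccc(OC)c(OC)c3)nc3cc(-c4ccccc4)nn23)cc1` gives 16400 nM in this assay; compound 2 `COc1ccc(C(=O)/C=C/c2cc(-c3ccc(OC)cc3)n3nc(-c4ccccc4)cc3n2)cc1` gives 8500 nM; compound 3 `COc1ccc(-c2cc(/C=C/C(=O)c3ccccc3)nc3cc(-c4ccccc4)nn23)cc1` gives 13700 nM. Compound 1 sits at the high end of these three numbers, yet none of them is separated from the others beyond the scatter: a 1.9-fold lower number from compound 1 to compound 2 (0.29 log units; within the scatter), a 1.2-fold lower number from compound 1 to compound 3 (0.08 log units; within the scatter), and a 1.6-fold higher number from compound 2 to compound 3 (0.21 log units; within the scatter).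

Compound 4 `COc1ccc(C(=O)/C=C/c2cc(-c3cc(OC)c(OC)c(OC)c3)n3nc(-c4ccccc4)cc3n2)cc1OC` differs from compound 1 by 3,4,5-trimethoxyphenyl in place of 4-methoxyphenyl on an aromatic carbon. Within the data shown here, no measured step touches this aryl ring; the steps in hand concern methoxy groups elsewhere and the aryl on the carbonyl carbon, and all stayed within the scatter. Compound 4 is therefore expected to give about 12000 nM in this assay, between 4500 nM and 32000 nM, which is an estimated 1.4-fold lower number from compound 1 to compound 4 (0.14 log units; within the scatter).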

Compound 4, half-maximal inhibitory concentration: 29900 nM
Beside the measured number, compound 4's estimate is 2.5-fold (0.40 log units) below it; measured number inside the range.
By their numbers in this assay, from the lowest: compounds 2, 3, 1 and 4 (each within the scatter of the next, the first and the last beyond it).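

Among these compounds, this is the first step at the aromatic carbon next to the ring nitrogen: in this assay, 3,4,5-trimethoxyphenyl in place of 4-methoxyphenyl gives a 1.8-fold higher number from compound 1 to compound 4 (0.26 log units; within the scatter) and so stays inside the scatter. Among the compounds shown here, the added methoxy groups therefore produce no readable change at this position, as with the earlier steps at other places on the series. No supporting evidence is available to explain this result. Still open, from the compounds shown here alone, is whether an amine or a carboxylic acid on this aryl ring, or an unsubstituted phenyl here, would move the number beyond the scatter.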